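Cyano to methoxy on the benzyl ring: compound 3 ahead

A few compounds are considered here, and "the series" means these few. Any claim that something is new, unique, unknown or untested is made for them only; others in the source may bear on it.

compound 1 `O=c1ccoc2cc(OCc3cn(Cc4ccccc4F)nn3)ccc12`: 29800 nM
compound 2 `N#Cc1ccc(Cn2cc(COc3ccc4c(=O)ccoc4c3)nn2)cc1`: limit only, > 100000 nM

In a functional assay on MDA-MB-231 cells (Homo sapiens) for cytotoxicity, read by MTT assay, with a stated time of 48 h (on this read-out higher numbers stand for weaker inhibition and lower numbers for stronger inhibition), compound 1 gives 29800 nM. For compound 2 the same assay reports no number but a limit, > 100000 nM, namely (the limit of > 100000 nM in this assay, at which 1 of the 2 values shown sits). Among the compounds with values here, the only measured step, an at least 3.3-fold higher number from compound 1 to compound 2 (0.52 log units; beyond the scatter), shows that the group on the benzyl ring moves the read-out. Within the data shown here, compound 3 `COc1ccc(Cn2cc(COc3ccc4c(=O)ccoc4c3)nn2)cc1` differs from compound 2 by methoxy in place of cyano on an aromatic carbon; no measured step covers this change, and the limit for compound 2 gives no fixed starting number. Compound 3 is expected near 60000 nM, range 20000 nM to 150000 nM. That estimate amounts to an at least 1.6-fold lower number from compound 2 to compound 3 (0.22 log units; that floor lies within the scatter), with a fair chance that only a limit is reported again.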

Compound 3, half-maximal inhibitory concentration: > 100000 nM
Compound 3: a limit, no number (the forecaster's own chance of this, stated with the estimate: 45%); middle value at least 1.6-fold (0.22 log units) from the limit.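

Moving from the 2-fluorophenyl to the 4-methoxyphenyl group gives an at least 3.3-fold higher number from compound 1 to compound 3 (0.52 log units; beyond the scatter). The rise seen with the 4-cyanophenyl group, an at least 3.3-fold higher number from compound 1 to compound 2 (0.52 log units; beyond the scatter), is therefore not confined to cyano: a second group at that place also loses the measurable reading. In this assay, the step between compound 2 and compound 3 cannot be read, as each compound has a limit and not a number: the limit of > 100000 nM in this assay, at which 2 of the 3 values shown sit.

Only compound 1 gives a number, and the compounds shown do not separate the fluoro group from its place on the ring. From the compounds shown here alone, how an amine or a carboxylic acid on the benzyl ring would read remains open.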